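Alpha-methyl on the benzylic linker of compound 2

A few compounds are considered here, and "the series" means these few. Any claim that something is new, unique, unknown or untested is made for them only; others in the source may bear on it.

Measured compounds:
compound 1 `CCC(=O)Nc1cccnc1NCc1ccc(-c2ccccc2C(=O)OC)cc1`: 119 nM
compound 2 `CNC(=O)c1ccccc1-c1ccc(CNc2nccc(C)c2NC(=O)CC(F)(F)F)cc1`: 11 nM

In an in vitro assay on CHO cells for inhibition of B1 bradykinin receptor (Homo sapiens) (on this read-out higher numbers stand for weaker inhibition and lower numbers for stronger inhibition), compound 2 gives the lowest number of the two; compound 1 sits higher, a gap beyond the scatter.

Compound 3 `CNC(=O)c1ccccc1-c1ccc([C@@H](C)Nc2nccc(C)c2NC(=O)CC(F)(F)F)cc1` differs from compound 2 by a single change: methyl in place of hydrogen on a saturated chain carbon bound to an aromatic carbon and a nitrogen on an aromatic ring. Among the compounds with values here, no measured pair in this set shows such a change, so the size of the step is open.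

Compound 3 is expected to stay close to compound 2, with a step of a 1.4-fold lower number from compound 2 to compound 3 (0.14 log units; within the scatter) that may well lie within the scatter, estimated at 8 nM (range 3 nM to 25 nM).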

Compound 3, inhibition constant: 6 nM
Estimate against measurement, compound 3: 1.3-fold (0.12 log units) above, within the range that was stated.
By their numbers in this assay, from the lowest: compounds 3 and 2 (each within the scatter of the next); then compound 1.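

In this assay the methyl on the saturated chain carbon bound to an aromatic carbon and a nitrogen on an aromatic ring gives a 1.8-fold lower number from compound 2 to compound 3 (0.26 log units; within the scatter) and so leaves compound 2 and compound 3 reading alike. Within the data shown here, this carbon therefore accepts one methyl, in the single configuration drawn for compound 3, with the reading held within the scatter. Nothing available bears on why the reading holds.

Open, as far as these compounds go, are the opposite configuration at this carbon and an ethyl group or a second methyl there. Also open, from the compounds shown here alone, is whether the same methyl reads alike on the core of compound 1.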